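Aryl oxazole ketone series: amino to hydroxyl at new position

The compounds below may be only part of what the source reports. "The series", "measured", "known", "first", "only" and "open" are said of these compounds alone.

Going by the values given here, compound 1 `Nc1ccccc1-c1cnc(C(=O)CCCCCCc2ccccc2)o1` stands at the higher of the two numbers so far in an assay (Rattus norvegicus) for inhibition of Fatty-acid amide hydrolase 1 (Homo sapiens) (a lower number here means a stronger inhibitor, a higher number a weaker inhibitor), where compound 1 gives 750 nM. Among the compounds with values here, its nearest neighbour is compound 2 `Nc1cccc(-c2cnc(C(=O)CCCCCCc3ccccc3)o2)c1`, which in this assay gives 19 nM; the step of a 39-fold lower number from compound 1 to compound 2 (1.60 log units; beyond the scatter) is the only measured change.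

Compound 3 `O=C(CCCCCCc1ccccc1)c1ncc(-c2cccc(O)c2)o1` differs from compound 1 by 3-hydroxyphenyl in place of 2-aminophenyl on an aromatic carbon. Part of this change, the move from the 2-position to the 3-position of the phenyl ring, is covered by the step from compound 1 to compound 2; the swap of an amino for a hydroxyl group has no measured counterpart. The expectation for compound 3 is therefore a marked fall in the number in this assay, of a size a 19-fold lower number from compound 1 to compound 3 (1.27 log units; beyond the scatter), because the step of a 39-fold lower number from compound 1 to compound 2 (1.60 log units; beyond the scatter) was large and beyond the scatter. Compound 3 is estimated at 40 nM, with a range of 10 nM to 200 nM.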

Compound 3, inhibition constant: 50 nM
For compound 3 the middle estimate is 1.3-fold (0.10 log units) below the measured one, and the stated range covers the measured number.
By their numbers in this assay, from the lowest: compound 2; then compound 3; then compound 1.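

In this assay, 3-hydroxyphenyl in place of 2-aminophenyl gives a 15-fold lower number from compound 1 to compound 3 (1.18 log units; beyond the scatter), so the large fall in the number seen with 3-aminophenyl does not depend on keeping the amino group. The identity of the group still counts, however: hydroxy in place of amino gives a 2.6-fold higher number from compound 2 to compound 3 (0.42 log units; beyond the scatter), a modest step but beyond the scatter, which leaves 3-aminophenyl with the lower number of this pair. No supporting data bear on the reason for either step.

The compounds shown leave open whether a carboxylic acid or a methoxy group in place of the hydroxy group would hold the number near that of compound 3. They also leave open whether an unsubstituted phenyl ring would do so, and whether these steps would keep their size with a longer chain on the ketone.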